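The source may report more compounds than this note shows. Statements on the series, on what has been measured and on what is new or still open speak of the compounds shown alone.

Working notes on the series. Among the measured compounds shown here, compound 3, `CCCCCCCCCNC[C@@H]1OC[C@H](N)[C@@H]1O`, gives the lowest of the three numbers so far in a functional assay on PC-3 cells (Homo sapiens) for antiproliferative activity, read by MTT assay, with a stated time of 72 h (on this read-out higher numbers stand for weaker inhibition and lower numbers for stronger inhibition), at 2030 nM. Its nearest neighbour on this read-out is compound 2, `CCCCCCCCCCCCNC[C@@H]1OC[C@H](N)[C@H]1O`, which gives 2380 nM, a gap within the scatter; the furthest is compound 1, `CCCCCCCCCCCNC[C@@H]1OC[C@H](N)[C@H]1O`, which gives 10000 nM, a gap beyond the scatter. For the measured compounds named here, the one step measured so far, a 4.2-fold lower number from compound 1 to compound 2 (0.62 log units; beyond the scatter), concerns chain length and not configuration.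

Compound 4, `CCCCCCCCCNC[C@@H]1OC[C@H](N)[C@H]1O`, is the next point: the two compounds have the same atoms and bonds and differ only in configuration as drawn: 1 of 3 stereo elements differ; a stereocentre at a saturated ring carbon is drawn S in compound 3 and R in compound 4. Going by the values given here, no measured step changes a stereocentre, so nothing here tells the size or direction of the effect of inverting the ring carbon. Compounds 1 and 2 share the configuration drawn for compound 4, and both give higher numbers than compound 3, but each also carries a different chain, so this is not a clean comparison. With that caveat, compound 4 is expected to give a somewhat higher number than compound 3, a step of a 2.0-fold higher number from compound 3 to compound 4 (0.29 log units; within the scatter), with wide uncertainty. The estimate for compound 4 in this assay is 4000 nM, in a range from 1200 nM to 15000 nM.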

Compound 4, half-maximal inhibitory concentration: 7650 nM
Beside the measured number, compound 4's estimate is 1.9-fold (0.28 log units) below it; the measured number falls inside the stated range.
By their numbers in this assay, from the lowest: compounds 3 and 2 (each within the scatter of the next); then compounds 4 and 1 (each within the scatter of the next).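

In this assay the ring stereocentre now proves to matter on its own, with a 3.8-fold higher number from compound 3 to compound 4 (0.58 log units; beyond the scatter): this gap lies beyond the scatter and can be set down to the inversion alone because nothing else separates the pair: the fact that compounds 3 and 4 differ only in the configuration as drawn. Chain length can now be read at a single configuration: a 3.2-fold higher number from compound 2 to compound 4 (0.51 log units; beyond the scatter) is beyond the scatter, while a 1.3-fold lower number from compound 1 to compound 4 (0.12 log units; within the scatter) stays within it. With this configuration, then, only the longest chain shown gives a clearly lower number, and the two shorter chains cannot be told apart.

From the compounds shown here alone, whether the inversion has the same size on the longer chains stays open, as does the effect of inverting the other two stereo elements. Also open, going by these compounds, is how a phenyl group or a longer chain in place of the present chains would read.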